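The source may report more compounds than this note shows. Statements on the series, on what has been measured and on what is new or still open speak of the compounds shown alone.

Compound 1, `O=C1C(Nc2cccc(F)c2)=CC(=O)c2ncccc21`, in a functional assay (aorta) for inhibition, with Rattus norvegicus as the target (on this read-out lower numbers stand for an effect already at smaller amounts and higher numbers for an effect only at larger amounts of compound), gives 805 nM. Compound 2, `O=C1C(Nc2ccc(F)c(F)c2)=CC(=O)c2ncccc21`, in this assay gives 251 nM. Compound 3, `O=C1C=C(Nc2ccc(F)cc2F)C(=O)c2cnccc21`, in this assay gives 430 nM.

Compound 1 and compound 3 are built on different cores; the difference between the two cores is not broken down here. From compound 1 to compound 2 the change is fluoro in place of hydrogen on an aromatic carbon, and it gave a 3.2-fold lower number from compound 1 to compound 2 (0.51 log units; beyond the scatter). The unmeasured compound 4, `O=C1C=C(Nc2ccc(F)c(F)c2F)C(=O)c2cnccc21`, arises from compound 3 by fluoro in place of hydrogen on an aromatic carbon. This is the same kind of change, not the same one: in compound 2 the entering fluoro is ortho to a fluoro group and para to a large group, in compound 4 it is ortho to two fluoro groups and meta to a large group. The number for compound 3 lies within the scatter of compound 2 and of compound 1, so no order can be read among these three.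

In this assay compound 4 is expected to show a 1.7-fold lower number from compound 3 to compound 4 (0.22 log units; within the scatter), a step leaning on the earlier one because a 3.2-fold lower number from compound 1 to compound 2 (0.51 log units; beyond the scatter) was measured, but kept smaller as the surroundings of the place differ. The estimate for compound 4 in this assay is 260 nM, expected to fall between 120 nM and 600 nM.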

Compound 4, half-maximal effective concentration: 1130 nM
Beside the measured number, compound 4's estimate is 4.3-fold (0.64 log units) below it; the whole stated range lies below it.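

In this assay the entering fluoro gave a 2.6-fold higher number from compound 3 to compound 4 (0.42 log units; beyond the scatter), which runs in the opposite direction to the earlier step. Set side by side, the two steps clearly part ways: the same change on two cores in this assay, a 3.2-fold lower number (0.51 log units; beyond the scatter) from compound 1 to compound 2 and a 2.6-fold higher number (0.42 log units; beyond the scatter) from compound 3 to compound 4, 8.4-fold (0.93 log units) apart, beyond the scatter of two such steps

So a lower number from this change on the core of compound 1 cannot be assumed on the core of compound 3, but the data do not show whether the core or the different place of the entering fluoro matters, as the two steps differ in both. The compounds shown carry only fluoro groups on the six-membered ring of carbon only. On these data alone, how a chloro group, a methoxy group or an amine at that place would behave on either core stays open.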